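Swapping chloro for methyl in compound 3

This account rests on a few compounds, and the source may have more. Where it says the series, first, only, none or still open, it means among the compounds named here.

Three related compounds have been tested so far in an ADME assay on HaCaT cells (Homo sapiens) for inhibition, read by sulforhodamine B assay, with a stated time of 48 h (a lower number here means a stronger inhibitor of growth, a higher number a weaker inhibitor of growth), and their readings are far from tight. In this assay compound 1 (`CCOC(=O)c1nn(-c2ccccc2)c(-c2ccc(Cl)cc2)c1CNC(C)(C)C`) gives 63500 nM; > 559000 nM (2 entries) across repeat entries. For compound 1 the entry with the sign is a limit, not a number. In this assay compound 2 (`CCOC(=O)c1nn(-c2ccc(Cl)cc2)c(-c2ccc([N+](=O)[O-])cc2)c1CNC(C)(C)C`) gives 10300 nM; 145000 nM (2 entries) across repeat entries that lie well apart. In this assay compound 3 (`CC(C)(C)NCc1c(C(=O)O)nn(-c2ccccc2)c1-c1ccc(Cl)cc1`) gives > 652000 nM as its only figure, and this is a limit, not a number.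

Compound 4 (`Cc1ccc(-c2c(CNC(C)(C)C)c(C(=O)O)nn2-c2ccccc2)cc1`) is not yet measured. It differs from compound 3 in one place (methyl in place of chloro on an aromatic carbon), with methyl in place of chloro on an aromatic carbon, so 4-chlorophenyl becomes 4-methylphenyl. Among the measured compounds shown here, no measured pair here shows this swap. Resting on compound 3 at > 652000 nM as a limit, the expected change in this assay is none beyond the usual scatter, in either direction. The expected step runs a number no higher from compound 3 to compound 4 (the limit leaves the size open) and remains only an estimate. For compound 4 the estimate is 650000 nM in this assay with an expected range from 150000 nM to 1000000 nM. There is a good chance that compound 4 will yield only a limit.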

Compound 4, concentration for 50% growth inhibition: > 688000 nM
Compound 4: only a limit was reported; the forecaster's own chance of this, stated with the estimate: 65%; middle value at least 1.0-fold (0.02 log units) from the limit.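

Compound 3 and compound 4 each gave only a limit, not a number, and no step can be read between them. The compounds shown leave open whether methyl in place of chloro, turning 4-chlorophenyl into 4-methylphenyl, changes growth inhibition at all.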